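The source may hold more compounds than are shown below. What is called first, only, known or untested is meant among the compounds shown, and "the series" means these compounds.

Compound 1, `COc1ccc(-n2cc(-c3ccc(OC)c(OC)c3)nn2)c(OC)c1`: "not determined" (no result reported) in a functional assay on MDA-MB-231 cells (Homo sapiens) for cytotoxicity, read by MTT assay; on this read-out lower numbers stand for stronger inhibition and higher numbers for weaker inhibition
Compound 2, `COc1ccc(-n2cc(-c3ccc(OC)c(O)c3)nn2)cc1`: > 10000 nM in this assay

Two compounds are recorded here, and neither carries a plain number in this assay. For compound 1 there is no result at all. The value of compound 2 in this assay is a limit, > 10000 nM, and not a measured figure. This is what places compound 2 among the entries: it sits at the limit of > 10000 nM in this assay, at which 1 of the 2 values shown sits, while the only other entry is blank. For the measured compounds named here, there is therefore no step between measured compounds from which a direction or size could be read.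

Compound 3, `COc1ccc(-n2cc(-c3ccc(OC)c(O)c3)nn2)c(OC)c1`, is not yet measured in this assay. Compared with compound 2 it differs by methoxy in place of hydrogen on an aromatic carbon. With nothing but a limit for compound 2 and no result for compound 1, the account can only carry the limit forward: compound 3 is expected to come out as another limit rather than a number, so that the step that the limit leaves unreadable from compound 2 to compound 3 is estimated to show no change beyond the scatter. On that basis compound 3 is estimated at 15000 nM, in a range from 4000 nM to 60000 nM.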

Compound 3, half-maximal inhibitory concentration: > 10000 nM
Compound 3 was reported as a limit; the forecaster's own chance of this, stated with the estimate: 80%; the middle value is on the limit's open side.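

In this assay compound 2 and compound 3 are both reported only as limits, so no step can be read between them. The compounds shown leave open where compound 2 and compound 3 would fall as plain numbers, and whether methoxy in place of hydrogen on an aromatic carbon changes the read-out at all.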